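The compounds below may be only part of what the source reports. "The series", "measured", "known", "first", "only" and "open" are said of these compounds alone.

Measured so far, in a functional assay on ML1 cells (Homo sapiens) for antiproliferative activity, read by WST assay, with a stated time of 3 days; a lower number here means a stronger inhibitor, a higher number a weaker inhibitor:
compound 1 `[N-]=[N+]=Nc1cc(=O)[nH]c(=O)n1[C@@H]1O[C@H](CO)[C@@H](O)[C@H]1O` — > 50000 nM, a limit of the assay
compound 2 `Nc1cc(=O)[nH]c(=O)n1[C@@H]1O[C@H](CO)[C@@H](O)[C@H]1O` — > 50000 nM, a limit of the assay
compound 3 `[N-]=[N+]=Nc1c(F)c(=O)[nH]c(=O)n1[C@@H]1O[C@H](CO)[C@@H](O)[C@H]1O` — 600 nM

Only compound 3 gives a number. The change fluoro in place of hydrogen on an aromatic carbon produces an at least 83-fold lower number from compound 1 to compound 3 (1.92 log units; beyond the scatter). The change amino in place of azido on an aromatic carbon gives a step that the two limits leave unreadable from compound 1 to compound 2, which cannot be sized because of the limit of > 50000 nM in this assay, at which 2 of the 3 values shown sit.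

Compound 4 `Nc1c(F)c(=O)[nH]c(=O)n1[C@@H]1O[C@H](CO)[C@@H](O)[C@H]1O` is not yet measured. It differs from compound 3 by amino in place of azido on an aromatic carbon. This is the same kind of change as from compound 1 to compound 2, though not the same: in compound 3 the carbon carrying the azido group is ortho to a fluoro group, which is absent in compound 1. The two cores differ by fluoro in place of hydrogen on an aromatic carbon.

Going by the values given here, the earlier amino-for-azido step is unreadable, so no measured size supports an expectation here; the only anchor is the number for compound 3. For compound 4 the step is estimated as a 5.0-fold higher number from compound 3 to compound 4 (0.70 log units; beyond the scatter), a weakening, with wide uncertainty. Compound 4 is therefore expected to give 3000 nM, between 600 nM and 30000 nM.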

Compound 4, half-maximal inhibitory concentration: 700 nM
Estimate against measurement, compound 4: 4.3-fold (0.63 log units) above; the measured number falls inside the stated range.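

In this assay, fluoro in place of hydrogen on an aromatic carbon now stands on a second core and gives an at least 71-fold lower number from compound 2 to compound 4 (1.85 log units; beyond the scatter). The change therefore carries over from the azido compounds to the amino compounds as a large step to a lower number, but neither size is exact, and the comparison stops here: the same change on two cores in this assay, an at least 83-fold lower number (1.92 log units; beyond the scatter) from compound 1 to compound 3 and an at least 71-fold lower number (1.85 log units; beyond the scatter) from compound 2 to compound 4; the limit leaves it open whether they differ Amino in place of azido on an aromatic carbon gives a 1.2-fold higher number from compound 3 to compound 4 (0.07 log units; within the scatter) on the fluoro-bearing core, whereas the same change on the core without fluoro cannot be read, and nothing shows that the result on the fluoro-bearing core applies there.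

The compounds shown leave open whether chloro, bromo or methyl in place of the fluoro group would also give a readable number in this assay. On these data alone, how a methoxy or dimethylamino group in place of the azido group would read on the fluoro-bearing core also stays open.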